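This account rests on a few compounds, and the source may have more. Where it says the series, first, only, none or still open, it means among the compounds named here.

Measured compounds in a functional assay on CHO-K1 cells for agonist activity at Orexin/Hypocretin receptor type 1 (Homo sapiens), read by FLIPR and calcium flux; on this read-out higher numbers stand for an effect only at larger amounts of compound and lower numbers for an effect already at smaller amounts:
Compound 1 `CCS(=O)(=O)NC1CCCN(C(C)=O)C1COC1CCC(C(C)C)CC1` gives > 100000 nM, a limit of the assay.
Compound 2 `CCS(=O)(=O)N[C@H]1CCCN(C(C)=O)[C@H]1CO[C@H]1CC[C@H](C(C)C)CC1` gives > 100000 nM, a limit of the assay.
Compound 3 `CC(=O)N1CCC[C@H](NS(C)(=O)=O)[C@@H]1CO[C@H]1CC[C@@H](C(C)C)CC1` gives > 100000 nM, a limit of the assay.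

Compound 3 therefore stands at the same limit as the other two; no number is known for it, only that no effect was seen up to that concentration. Going by the values given here, the only pair that differs in one place, compound 1 and compound 2, gives a step that the two limits leave unreadable from compound 1 to compound 2, because of the limit of > 100000 nM in this assay, at which 3 of the 3 values shown sit, the size of that step cannot be read. Compound 2 and compound 3 differ in the group on the sulfonyl sulfur, but both sit at the limit and show nothing beyond that.

Compound 4 `CC(=O)N1CCC[C@H](NS(=O)(=O)C(C)C)[C@@H]1CO[C@H]1CC[C@@H](C(C)C)CC1` is not yet measured. It differs from compound 3 as follows: isopropyl in place of methyl on a sulfonyl sulfur. Among the compounds with values here, no measured step bears on this change; every value is a limit, so nothing in the numbers points to a direction or a size. The expectation for compound 4 is that it remains at or near the same limit, with the step from compound 3 estimated as a number no higher from compound 3 to compound 4 (the limit leaves the size open). The estimated value for compound 4 in this assay is 100000 nM, in the range 20000 nM to 100000 nM.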

Compound 4, half-maximal effective concentration: > 100000 nM
Compound 4 ended at the assay's limit; the forecaster's own chance of this, stated with the estimate: 85%; the middle value sits exactly at the limit.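

In this assay compound 4 gives > 100000 nM, a limit of the assay and not a number. No step can be read from compound 3 to compound 4, with isopropyl in place of methyl on a sulfonyl sulfur, because of this: the limit of > 100000 nM in this assay, at which 4 of the 4 values shown sit.

The compounds shown leave open which structural change, if any, would bring a measurable effect in this series.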